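The compounds below may be only part of what the source reports. "The series", "measured", "known", "first", "only" and "open" are said of these compounds alone.

Working notes on a small set of acrylonitrile amides tested in a functional assay on MCF7 cells (Homo sapiens) for inhibition, read by MTT assay, with a stated time of 72 h; a higher number here means a weaker inhibitor of growth, a lower number a stronger inhibitor of growth.

Compound 1 `COc1ccc(CNC(=O)/C(C#N)=C/c2ccco2)cc1` carries an unsubstituted furan ring; in this assay compound 1 gives 27000 nM. Among the compounds with values here, compound 2 `COc1ccc(CNC(=O)/C(C#N)=C/c2ccc(Cl)o2)cc1` differs from it by chloro in place of hydrogen on an aromatic carbon and gives 9000 nM; the step of a 3.0-fold lower number from compound 1 to compound 2 (0.48 log units; beyond the scatter) is the only measured change in this set.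

Compound 3 `N#C/C(=C\c1ccccc1)C(=O)NCc1ccc(Cl)c(Cl)c1` belongs to a second core: a phenyl ring on the acrylonitrile side and a dichlorobenzyl amide. The difference between the two cores is not broken down here. In this assay compound 3 gives 29000 nM, which sits within the scatter of compound 1 and beyond the scatter of compound 2.

Compound 4 `N#C/C(=C\c1ccc(Cl)cc1)C(=O)NCc1ccc(Cl)c(Cl)c1` is not yet measured. It differs from compound 3 by chloro in place of hydrogen on an aromatic carbon. This is the same kind of change as that from compound 1 to compound 2, but not the same: in the measured pair the chloro enters on a five-membered aromatic ring with one oxygen, next to the ring oxygen, two ring bonds from the ring atom that bears a large group, whereas in compound 4 it enters on a six-membered aromatic ring of carbon only, para to a large group. Within the data shown here, with no measured example of a chloro on that ring, the expectation is a step of similar direction but less certain size than a 3.0-fold lower number from compound 1 to compound 2 (0.48 log units; beyond the scatter). The estimated step is a 1.9-fold lower number from compound 3 to compound 4 (0.29 log units; within the scatter). The value expected for compound 4 in this assay is 15000 nM, with a range from 5000 nM to 40000 nM.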

Compound 4, concentration for 50% growth inhibition: 21000 nM
For compound 4 the middle estimate is 1.4-fold (0.15 log units) below the measured one; the range from low to high includes it.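

In this assay, chloro in place of hydrogen on the six-membered aromatic ring of carbon only, para to a large group, gives a 1.4-fold lower number from compound 3 to compound 4 (0.14 log units; within the scatter), so on the core of compound 3 this change cannot be told apart from repeat measurement. Set beside the step on the core of compound 1, the two steps do not differ by more than two such steps can be expected to scatter: the same change on two cores in this assay, a 3.0-fold lower number (0.48 log units; beyond the scatter) from compound 1 to compound 2 and a 1.4-fold lower number (0.14 log units; within the scatter) from compound 3 to compound 4, 2.2-fold (0.34 log units) apart, within the scatter of two such steps

The pair of steps is therefore compatible with one shared size for the change on both cores, but it does not establish this: one step lies beyond the scatter and the other within it, and two pairs, with the chloro on different rings, cannot separate an effect of the core from an effect of the ring that carries the chloro.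

On these data alone, whether the same ring position responds at all to groups other than chloro, such as bromo, an amine or a carboxylic acid, remains open. The two cores also differ in more than one place, so the contributions of the ring on the acrylonitrile side and of the benzyl amide remain unresolved.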